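A few compounds are considered here, and "the series" means these few. Any claim that something is new, unique, unknown or untested is made for them only; others in the source may bear on it.

Of the compounds shown here, three sharing one core have been tested in a functional assay on U-87MG ATCC cells for antiproliferative activity against U-87 MG (Homo sapiens), read by MTT assay, with a stated time of 48 h, tested at 5 uM; on this read-out lower numbers stand for a stronger effect and higher numbers for a weaker effect at the one concentration tested. Compound 1 `Cc1nc(-c2ccc(Cl)cc2)sc1C(=O)CSc1nc(-c2cccc(Cl)c2)c(C#N)c(=O)[nH]1` gives 80.2%. Compound 2 `COc1ccc(-c2nc(C)c(C(=O)CSc3nc(-c4ccc(Cl)c(Cl)c4)c(C#N)c(=O)[nH]3)s2)cc1` gives 101%. Compound 3 `COc1ccc(-c2nc(C)c(C(=O)CSc3nc(-c4ccccc4)c(C#N)c(=O)[nH]3)s2)cc1` gives 99%, the second highest of the three numbers: it sits within the scatter of compound 2, and beyond the scatter of compound 1, whose number is lower. The step of a number 2 percentage points lower from compound 2 to compound 3 (within the scatter) shows that phenyl in place of 3,4-dichlorophenyl left the read-out unchanged within the scatter.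

Compound 4 `COc1ccc(-c2nc(C)c(C(=O)CSc3nc(-c4cccc(Cl)c4)c(C#N)c(=O)[nH]3)s2)cc1` is not yet measured. It differs from compound 3 by chloro in place of hydrogen on an aromatic carbon. Among the measured compounds shown here, the only measured step that bears on this change is a number 2 percentage points lower from compound 2 to compound 3 (within the scatter), which stayed within the scatter, so a chloro entering this ring is expected to give a step of a number 2 percentage points lower from compound 3 to compound 4 (within the scatter), none beyond the scatter. Compound 1 also carries a 3-chlorophenyl but differs elsewhere, so its lower number cannot be tied to this change alone. Compound 4 is therefore estimated at 97%, with a range from 84% to 106%.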

Compound 4, a percentage reported as activity, at one concentration (the size of the read-out at that concentration, not a potency): 95.7%
The estimate for compound 4 lay 1.3 percentage points above the measured number; measured number inside the range.
By their numbers in this assay, from the lowest: compound 1; then compounds 4, 3 and 2 (each within the scatter of the next).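

In this assay, chloro in place of hydrogen gives a number 3.3 percentage points lower from compound 3 to compound 4 (within the scatter), and hydrogen in place of chloro gives a number 5.3 percentage points lower from compound 2 to compound 4 (within the scatter), so phenyl, 3-chlorophenyl and 3,4-dichlorophenyl cannot be told apart at this position while the methoxy group stays in place elsewhere. The clearer change lies at that other place: with the 3-chlorophenyl held fixed, methoxy in place of chloro gives a number 15.5 percentage points higher from compound 1 to compound 4 (beyond the scatter), which ties the lower number of compound 1 to that chloro rather than to the 3-chlorophenyl. No measurement at hand explains either result.

Whether that chloro would have the same effect alongside a phenyl or a 3,4-dichlorophenyl remains open, since only one such pair is shown. Also open, going by these compounds, is how a methyl, an amine or a carboxylic acid would fare in place of either chloro.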